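Chloro for Trifluoromethyl: Expected Cytotoxicity of Compound 4

The source may report more compounds than this note shows. Statements on the series, on what has been measured and on what is new or still open speak of the compounds shown alone.

Compounds measured so far in an ADME assay on HEK293 cells (Homo sapiens) for cytotoxicity, with a stated time of 72 h; on this read-out lower numbers stand for an effect already at smaller amounts and higher numbers for an effect only at larger amounts of compound:
Compound 1 `Cc1cc(NC(=O)Nc2ccc(C)c(Cl)c2)c2ccccc2n1` gives > 25000 nM, which is a limit of the assay.
Compound 2 `Cc1cc(NC(=O)Nc2cccc(F)c2)c2ccccc2n1` gives > 25000 nM, which is a limit of the assay.
Compound 3 `Cc1cc(NC(=O)Nc2cccc(C(F)(F)F)c2)c2ccccc2n1` gives 16000 nM.

Among the measured compounds shown here, compound 3 thus holds the only actual number among the three; the other two results are limits rather than numbers. For the measured compounds named here, the only measured step, an at least 1.5-fold lower number from compound 2 to compound 3 (0.19 log units; that floor lies within the scatter), moves from a limit to a number, and its floor lies within the usual scatter.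

Compound 4 `Cc1cc(NC(=O)Nc2cccc(Cl)c2)c2ccccc2n1` differs from compound 3 in one place: chloro in place of trifluoromethyl on an aromatic carbon. Going by the values given here, no measured step covers this exact exchange. The closest guide is that compound 1, which also carries chloro on its outer ring, sits at the limit (the limit of > 25000 nM in this assay, at which 2 of the 3 values shown sit), as does compound 2 after the step of an at least 1.5-fold lower number from compound 2 to compound 3 (0.19 log units; that floor lies within the scatter). The expectation is therefore a small move back toward that limit, a 1.4-fold higher number from compound 3 to compound 4 (0.14 log units; within the scatter), not beyond the scatter. Compound 4 is expected to give about 22000 nM, with a range from 12000 nM to 40000 nM in this assay.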

Compound 4, half-maximal effective concentration: 21000 nM
The estimate for compound 4 lay 1.0-fold (0.02 log units) above the measured number; the range from low to high includes it.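

In this assay, chloro and trifluoromethyl at this place on the outer ring cannot be told apart, with a 1.3-fold higher number from compound 3 to compound 4 (0.12 log units; within the scatter). Chloro in place of fluoro gives an at least 1.1-fold lower number from compound 2 to compound 4 (0.07 log units; that floor lies within the scatter), and hydrogen in place of methyl gives an at least 1.1-fold lower number from compound 1 to compound 4 (0.07 log units; that floor lies within the scatter), so these two steps set only floors and show no real difference. Compound 4 therefore adds a second actual number, yet the read-out still cannot rank the four compounds, and some of the results remain limits of the assay: the limit of > 25000 nM in this assay, at which 2 of the 4 values shown sit.

As far as these compounds go, whether an amine or a carboxylic acid at this place would give a number clearly apart from these stays open. From the compounds shown here alone, the actual numbers behind the limits of compound 1 and compound 2 also stay open.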